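The source may report more compounds than this note shows. Statements on the series, on what has been measured and on what is new or still open speak of the compounds shown alone.

Compound 1 `CCOC(=O)C1=C(N/C=N/c2cccnc2Cl)Nc2[nH]nc(C)c2C1c1ccc(N(C)C)cc1` was tested in a functional assay on MCF7 cells (Homo sapiens) for inhibition, read by MTT assay, with a stated time of 48 h (a higher number here means a weaker inhibitor, a lower number a stronger inhibitor), and gave 4180 nM. Among the three compounds with numbers, compound 1 stands lowest, so it is the strongest inhibitor of the set. Compound 2 `CCOC(=O)C1=C(N/C=N/c2ccc([N+](=O)[O-])cc2)Nc2[nH]nc(C)c2C1c1ccc(N(C)C)cc1` gives 58600 nM, and compound 3 `CCOC(=O)C1=C(N/N=C(/Cl)C#N)Nc2[nH]nc(C)c2C1c1ccc(N(C)C)cc1` gives 23200 nM; the step of a 14-fold higher number from compound 1 to compound 2 (1.15 log units; beyond the scatter) is large, and the step of a 5.6-fold higher number from compound 1 to compound 3 (0.74 log units; beyond the scatter) is modest.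

Compound 4 `CCOC(=O)C1=C(N/N=C(/C#N)C(=O)OCC)Nc2[nH]nc(C)c2C1c1ccc(N(C)C)cc1` is not yet measured. It differs from compound 1 in one place: a group of 9 heavy atoms (5 carbon, 2 nitrogen, 2 oxygen; no ring) in place of a group of 9 heavy atoms (6 carbon, 2 nitrogen, 1 chlorine; one six-membered aromatic ring with 1 hetero atom), on an amine nitrogen. For the measured compounds named here, the change that bears on it most closely is the one from compound 1 to compound 3, where a chain without a ring, also carrying a nitrile, replaced the same ring-bearing group on the same amine nitrogen and gave a 5.6-fold higher number from compound 1 to compound 3 (0.74 log units; beyond the scatter). Compound 4 keeps the ring-free chain of that kind and adds an ethyl ester, so a weakening of a similar modest size is expected, with a higher number than compound 1 in this assay.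

For compound 4 the expected step is a 4.8-fold higher number from compound 1 to compound 4 (0.68 log units; beyond the scatter). The estimate for compound 4 in this assay is 20000 nM, with a likely range from 6000 nM to 70000 nM.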

Compound 4, half-maximal inhibitory concentration: 35600 nM
Estimate against measurement, compound 4: 1.8-fold (0.25 log units) below, and the stated range covers the measured number.
By their numbers in this assay, from the lowest: compound 1; then compounds 3, 4 and 2 (each within the scatter of the next, the first and the last beyond it).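

With the ring-bearing group on the amine nitrogen replaced by a ring-free group of the same heavy-atom count, the result is an 8.5-fold higher number from compound 1 to compound 4 (0.93 log units; beyond the scatter), so the smaller heavy-atom count of the chain in compound 3 is not needed for a loss of this kind. Between the two ring-free chains, the one with an ethyl ester and the one with chlorine, the result is a 1.5-fold higher number from compound 3 to compound 4 (0.19 log units; within the scatter), a gap within the scatter of repeated measurements, so this assay does not separate them. The step of a 1.6-fold lower number from compound 2 to compound 4 (0.22 log units; within the scatter) is also within the scatter, and since compound 2 keeps a six-membered aromatic ring, a ring alone does not match compound 1, which remains the strongest inhibitor of the four.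

From the compounds shown here alone, it remains open whether the 2-chloropyridin-3-yl group of compound 1 owes its standing to the chlorine or to the ring nitrogen, which a plain phenyl or a 2-chlorophenyl group would help to test, and how a carboxylic acid or an amide in place of the ethyl ester would read. No measurement shown here bears on the cause of these steps.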